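Morpholine for thiomorpholine on the thiocarbonyl in this series

The source may report more compounds than this note shows. Statements on the series, on what has been measured and on what is new or still open speak of the compounds shown alone.

Working notes on the series. Two members have been measured. Compound 1 `N/C(=N\NC(=S)N1CCOCC1)c1ccccn1` carries a morpholin-4-yl on the thiocarbonyl carbon; in a functional assay on A-431 cells (Homo sapiens) for cytotoxicity, read by MTT assay, with a stated time of 72 h, tested at 100 uM (a lower number here means less inhibition of growth, a higher number more inhibition of growth at the concentration tested), compound 1 gives 84.6%. Compound 2 `Cc1cccc(/C(N)=N/NC(=S)N2CCSCC2)n1` carries a thiomorpholin-4-yl at that position and differs from compound 1 in more than one place; in this assay compound 2 gives 80.7%. Going by the values given here, the two numbers sit within the usual scatter of each other, so no order between them can be read, and since no measured pair differs in one place only, no single step is known.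

Compound 3 `Cc1cccc(/C(N)=N/NC(=S)N2CCOCC2)n1` is compound 2 with one change: morpholin-4-yl in place of thiomorpholin-4-yl on a thiocarbonyl carbon. Whether this exchange by itself moves the read-out cannot be taken from compound 1 and compound 2, which differ from each other in two places. With nothing in the measured pair pointing to a shift beyond the scatter, the step of a number 1.3 percentage points higher from compound 2 to compound 3 (within the scatter) is expected to be small, in no settled direction. Compound 3 is estimated at 82%, within 70% to 92%.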

Compound 3, percent growth inhibition at one concentration: 84.8%
For compound 3 the middle estimate is 2.8 percentage points below the measured one; measured number inside the range.
By their numbers in this assay, from the lowest: compounds 2, 1 and 3 (each within the scatter of the next).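

In this assay the exchange on the thiocarbonyl carbon can now be read by itself, and the step is a number 4.1 percentage points higher from compound 2 to compound 3 (within the scatter) for morpholin-4-yl in place of thiomorpholin-4-yl, with the ring size and the counted donors and acceptors unchanged. The same compound also isolates the second difference that was mixed into the earlier pair, with a number 0.2 percentage points higher from compound 1 to compound 3 (within the scatter) for methyl in place of hydrogen on an aromatic carbon, so neither single change moves the read-out beyond the scatter, and the earlier comparison of two differences now resolves into two small steps. No supporting measurement bears on either step.

Going by these compounds, what stays open is whether this position tolerates anything other than these two rings: a piperidin-1-yl, a 4-methylpiperazin-1-yl or an open-chain dimethylamino group on the thiocarbonyl carbon could show whether the ring hetero atom matters at all. On the aromatic carbon, a methoxy or a chlorine in place of the methyl would likewise test whether the flat result holds beyond methyl and hydrogen.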